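The source may report more compounds than this note shows. Statements on the series, on what has been measured and on what is new or still open speak of the compounds shown alone.

Working notes on the series. In an assay on isolated protein for binding affinity to B1 bradykinin receptor (Homo sapiens) (a lower number here means a stronger inhibitor, a higher number a weaker inhibitor), compound 2 `COC(=O)C1CCCCC1c1ccc(CNc2nccc(C)c2NC(=O)CC#N)cc1` gives 2.2 nM, the lowest of the two numbers available. Compound 3 `COC(=O)C1C2CCC(CC2)C1c1ccc(CNc2nccc(C)c2NC(=O)CC#N)cc1`, which carries a bridged ring at the same position, gives 54 nM in this assay, a clearly higher value. Compound 1 `COC(=O)N1CCCCC1c1ccc(CNc2nccc(C)c2NC(=O)CC#N)cc1` sits at the limit of this assay, > 5000 nM; this is a limit of the measurement and not a number (the limit of > 5000 nM in this assay, at which 1 of the 3 values shown sits). Among the measured compounds shown here, the only measured step at this position is therefore an at least 2200-fold lower number from compound 1 to compound 2 (3.35 log units; beyond the scatter), a large one.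

Compound 4 `COC(=O)c1cccn1-c1ccc(CNc2nccc(C)c2NC(=O)CC#N)cc1` is the next entry awaiting measurement. Against compound 2 the change is 2-(methoxycarbonyl)-1H-pyrrol-1-yl in place of 2-(methoxycarbonyl)cyclohexyl on an aromatic carbon. The step from compound 1 to compound 2 bears on it in that the ring at this position was exchanged; compound 4 keeps the ester on a ring carbon as in compound 2, but the ring itself becomes aromatic and five-membered, and the values of compound 2 and compound 3 show that an altered ring at this position is paid for with a higher number. A weakening step is therefore expected for compound 4, a 27-fold higher number from compound 2 to compound 4 (1.44 log units; beyond the scatter). The expected value for compound 4 is 60 nM, within 10 nM to 400 nM.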

Compound 4, inhibition constant in the B1 bradykinin receptor assay: 250 nM
Estimate against measurement, compound 4: 4.2-fold (0.62 log units) below; the measured number falls inside the stated range.
By their numbers in the B1 bradykinin receptor assay, from the lowest: compound 2; then compound 3; then compound 4. At a limit, above all of these: compound 1.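

In the B1 bradykinin receptor assay, keeping the ester on a ring carbon does not by itself hold the low number of compound 2 (2.2 nM): with a five-membered aromatic ring in place of the six-membered ring of carbon only, the step is a 110-fold higher number from compound 2 to compound 4 (2.06 log units; beyond the scatter). In the B1 bradykinin receptor assay, the step of an at least 20-fold lower number from compound 1 to compound 4 (1.30 log units; beyond the scatter) nonetheless places compound 4 well clear of compound 1, though that step rests on a limit of compound 1 and not on a number: the limit of > 5000 nM in the B1 bradykinin receptor assay, at which 1 of the 4 values shown sits. In a physicochemical assay for lipophilicity (on this read-out higher numbers stand for higher lipophilicity and lower numbers for lower lipophilicity), compound 2 gives 2.7 and compound 4 gives 2.4; the same exchange gives a number 0.30 log units lower from compound 2 to compound 4 (within the scatter), so this read-out does not separate the two compounds, while the binding numbers do.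

Compound 4 changes ring size and aromatic character together, and the two remain unseparated. A cyclopentyl or a phenyl ring carrying the same ester would divide them, and a carboxylic acid in place of the ester remains an open question.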